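Series notes: nitro in place of methoxy

The source may hold more compounds than are shown below. What is called first, only, known or untested is meant among the compounds shown, and "the series" means these compounds.

Measured so far in a functional assay on MCF7 cells (Homo sapiens) for antiproliferative activity, with a stated time of 5 days; on this read-out lower numbers stand for stronger inhibition and higher numbers for weaker inhibition
- compound 1 `CCCCc1ccc2[nH]c(-c3ccc(C(F)(F)F)cc3)c(/C=N/NC(=O)c3ccccc3)c2c1` gives 460 nM
- compound 2 `CCCCc1ccc2[nH]c(-c3ccc(C(F)(F)F)cc3)c(/C=N/NC(=O)c3ccc(OC)cc3)c2c1` gives 618 nM

Compound 2 at 618 nM lies within the scatter of compound 1 at 460 nM and so neither ranks ahead on these two numbers. Next comes compound 3 `CCCCc1ccc2[nH]c(-c3ccc(C(F)(F)F)cc3)c(/C=N/NC(=O)c3ccc([N+](=O)[O-])cc3)c2c1` with the change nitro in place of methoxy on an aromatic carbon and this puts nitro in place of methoxy on an aromatic carbon, para to a large group. Going by the values given here, one measured step bears on this place: a 1.3-fold higher number from compound 1 to compound 2 (0.13 log units; within the scatter) for methoxy in place of hydrogen, which stays within the scatter. Among the compounds with values here, no measured compound carries nitro, so that step guides only loosely. No shift beyond the scatter is expected in this assay and neither direction is favoured. The estimate amounts to an expected 1.1-fold lower number from compound 2 to compound 3 (0.06 log units; within the scatter) and no more than that. For compound 3 the expected value is 540 nM with an estimated range from 220 nM to 1300 nM on this read-out.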

Compound 3, half-maximal inhibitory concentration: 6340 nM
The estimate for compound 3 lay 12-fold (1.07 log units) below the measured number; the whole stated range lies below it.
By their numbers in this assay, from the lowest: compounds 1 and 2 (each within the scatter of the next); then compound 3.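

In this assay, the aromatic carbon para to a large group proves sensitive to what it carries: nitro in place of methoxy gives (a 10-fold higher number from compound 2 to compound 3 (1.01 log units; beyond the scatter)), and nitro in place of hydrogen gives (a 14-fold higher number from compound 1 to compound 3 (1.14 log units; beyond the scatter)). Hydrogen and methoxy at this place had stayed within the scatter of each other (a 1.3-fold higher number from compound 1 to compound 2 (0.13 log units; within the scatter)), so the position accepts some change but not every change, and of the three groups shown only nitro moves the number beyond the scatter. Nothing available here accounts for the weaker inhibition seen with nitro.

On these data alone, whether a nitrile, an amine or a carboxylic acid on this carbon would follow nitro or follow methoxy stays open. Also open, as far as these compounds go, is whether nitro on another carbon of the same ring would give a step of similar size.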